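Replacing 1H-indol-7-yl on the way to compound 4

The source may report more compounds than this note shows. Statements on the series, on what has been measured and on what is new or still open speak of the compounds shown alone.

Measured in a toxicity assay on MT4 cells (Homo sapiens) for cytotoxicity, read by MTT assay, with a stated time of 5 days; on this read-out lower numbers stand for higher toxicity in this test and higher numbers for lower toxicity in this test:
- compound 1 `Cc1cnc(Nc2ccc(C#N)cc2)nc1Nc1c(F)cc(-c2cc(F)nc(F)c2)cc1F`: 103000 nM
- compound 2 `Cc1cc(-c2ccnc3ccccc23)cc(C)c1Nc1ccnc(Nc2ccc(C#N)cc2)n1`: 3500 nM
- compound 3 `Cc1cc(-c2cccc3cc[nH]c23)cc(C)c1Nc1ccnc(Nc2ccc(C#N)cc2)n1`: 1000 nM

Compound 3 has the lowest number of the three, 1000 nM, so it is the most toxic in this small set. Compound 2 stands at 3500 nM, and compound 1 stands well higher at 103000 nM.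

The next compound is compound 4 `Cc1cc(-c2cc(F)nc(F)c2)cc(C)c1Nc1ccnc(Nc2ccc(C#N)cc2)n1`. It keeps the core of compound 3 and changes one group: 2,6-difluoropyridin-4-yl in place of 1H-indol-7-yl on an aromatic carbon. In words, 2,6-difluoropyridin-4-yl takes the place of 1H-indol-7-yl on an aromatic carbon, meta to two methyl groups.

Two pieces of evidence bear on this. Among the compounds with values here, the only measured swap of this kind, a 3.5-fold lower number from compound 2 to compound 3 (0.54 log units; beyond the scatter), was modest and exchanged quinolin-4-yl for 1H-indol-7-yl. Compound 1 carries the incoming 2,6-difluoropyridin-4-yl and gives 103000 nM, but its core differs from that of compound 4, so it can only indicate direction. Within the data shown here, no measured pair isolates the incoming group.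

A moderate move towards a higher number in this assay is therefore expected, somewhat larger than the measured swap. The expected change is a 6.0-fold higher number from compound 3 to compound 4 (0.78 log units; beyond the scatter). For compound 4 the estimated value is 6000 nM, with an expected range from 1500 nM to 30000 nM.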

Compound 4, half-maximal cytotoxic concentration: 6300 nM
Beside the measured number, compound 4's estimate is 1.1-fold (0.02 log units) below it; measured number inside the range.
By their numbers in this assay, from the lowest: compound 3; then compounds 2 and 4 (each within the scatter of the next); then compound 1.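

In this assay, the shared core now carries 2,6-difluoropyridin-4-yl, so the incoming group can be read directly at this place, para to a large group, rather than only through the differently built compound 1. The exchange for 1H-indol-7-yl gives a 6.3-fold higher number from compound 3 to compound 4 (0.80 log units; beyond the scatter), which shows that this position responds to a change from one aromatic group to another by more than the usual scatter. The exchange for quinolin-4-yl gives a 1.8-fold higher number from compound 2 to compound 4 (0.26 log units; within the scatter), so these two groups cannot be told apart here, and among the three groups compared on this core, only 1H-indol-7-yl stands apart from both others. Nothing available gives a measured reason for these differences.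

The compounds shown leave open whether the step from compound 3 to compound 4 goes with the loss of the hydrogen-bond donor, the five-membered ring or the two fluorine atoms, as all of these change together in this one exchange. A plain pyridin-4-yl group, or a non-aromatic amine such as morpholine, at the same place would be needed to separate these features and to show whether an aromatic group is required there at all.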